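This account rests on a few compounds, and the source may have more. Where it says the series, first, only, none or still open, it means among the compounds named here.

Compound 1 `COc1ccc(/C=N/NC(=O)Nc2ccc(Oc3ccnc(-c4nncn4CCN(C)C)c3)c(F)c2)c(OC)c1` is one of three compounds that have been examined in a functional assay on U-87MG ATCC cells (Homo sapiens) for cytotoxicity, read by MTT assay, with a stated time of 72 h; a lower number here means a stronger inhibitor, a higher number a weaker inhibitor. In this assay compound 1 gives 12600 nM, the second highest of the three numbers. Its nearest neighbour is compound 3 `CN(C)CCn1cnnc1-c1cc(Oc2ccc(NC(=O)N/N=C/c3cccc(Cl)c3Cl)cc2F)ccn1`, which in this assay gives 13200 nM; the step of a 1.0-fold higher number from compound 1 to compound 3 (0.02 log units; within the scatter) lies within the scatter. Compound 2 `CN(C)CCn1cnnc1-c1cc(Oc2ccc(NC(=O)N/N=C/c3ccc(F)cc3F)cc2F)ccn1` gives 1900 nM in this assay, and the step of a 6.6-fold lower number from compound 1 to compound 2 (0.82 log units; beyond the scatter) is beyond the scatter, as is the step of a 6.9-fold higher number from compound 2 to compound 3 (0.84 log units; beyond the scatter).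

Compound 4 `COc1cc(/C=N/NC(=O)Nc2ccc(Oc3ccnc(-c4nncn4CCN(C)C)c3)c(F)c2)ccc1O` has not been measured. It differs from compound 1 in one place: 4-hydroxy-3-methoxyphenyl in place of 2,4-dimethoxyphenyl on a carbon with a double bond to nitrogen. Among the measured steps, a 6.6-fold lower number from compound 1 to compound 2 (0.82 log units; beyond the scatter) and a 1.0-fold higher number from compound 1 to compound 3 (0.02 log units; within the scatter) both replace the same 2,4-dimethoxyphenyl on the same carbon; one is modest and beyond the scatter, the other within it. Going by the values given here, neither brings in a hydroxy group, so no measured step bears directly on the change from compound 1 to compound 4. The account therefore expects no step beyond the scatter, while allowing a wide range in this assay. The step from compound 1 to compound 4 is estimated as a 1.3-fold lower number from compound 1 to compound 4 (0.10 log units; within the scatter). Compound 4 is expected to give about 10000 nM in this assay, within 3000 nM to 30000 nM.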

Compound 4, half-maximal inhibitory concentration: > 100000 nM
Compound 4 ended at the assay's limit (the forecaster's own chance of this, stated with the estimate: 10%); at least 10-fold (1.00 log units) between middle value and limit.
By their numbers in this assay, from the lowest: compound 2; then compounds 1 and 3 (each within the scatter of the next). At a limit, above all of these: compound 4.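

Compound 4 stands at a limit of the assay, not at a number: the limit of > 100000 nM in this assay, at which 1 of the 4 values shown sits. The earlier replacements of 2,4-dimethoxyphenyl on this carbon with a double bond to nitrogen had produced one modest step and one within the scatter, whereas 4-hydroxy-3-methoxyphenyl gives an at least 7.9-fold higher number from compound 1 to compound 4 (0.89 log units; beyond the scatter), and the comparison with the other two groups gives an at least 7.5-fold higher number from compound 3 to compound 4 (0.87 log units; beyond the scatter) and an at least 52-fold higher number from compound 2 to compound 4 (1.72 log units; beyond the scatter), the last of these being large. Going by these compounds alone, this place on the compound can therefore carry a far bigger change in this assay than the earlier compounds showed, and the entering group differs from 2,4-dimethoxyphenyl in carrying a hydrogen-bond donor, although a single compound cannot tie the result to that donor.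

The compounds shown leave open whether the hydroxy group or the altered arrangement of the methoxy group accounts for the step, as both differ at once in compound 4. On these data alone, it also remains open whether a 4-hydroxyphenyl group with no methoxy group, or a 4-aminophenyl or 4-carboxyphenyl group on the same carbon, would give a similar result.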